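Carboxymethyl on the aniline nitrogen of compound 1

A few compounds are considered here, and "the series" means these few. Any claim that something is new, unique, unknown or untested is made for them only; others in the source may bear on it.

Measured so far in an assay for inhibition of Tryptophan 2,3-dioxygenase (Homo sapiens), with stated times of 10 min and 60 min; a lower number here means a stronger inhibitor, a higher number a weaker inhibitor:
compound 1 `Nc1cccc(CNc2cc(C(F)(F)F)cc3[nH]ncc23)c1` gives 2510 nM
compound 2 `Oc1ccc(CNc2cc(C(F)(F)F)cc3[nH]ncc23)cc1` gives 2550 nM
compound 3 `O=[N+]([O-])c1ccc(CNc2cc(C(F)(F)F)cc3[nH]ncc23)cc1` gives > 100000 nM, which is a limit of the assay and not a number

Of the two numbers shown, compound 1 has the lowest, but the step of a 1.0-fold higher number from compound 1 to compound 2 (0.01 log units; within the scatter) leaves the two compounds indistinguishable. Compound 3 sits at the limit of > 100000 nM in this assay, at which 1 of the 3 values shown sits. The step of an at least 39-fold higher number from compound 2 to compound 3 (1.59 log units; beyond the scatter) is the only large move in the set, and it changes a group on an aromatic carbon rather than anything on a nitrogen.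

Compound 4 `O=C(O)CNc1cccc(CNc2cc(C(F)(F)F)cc3[nH]ncc23)c1` differs from compound 1 by carboxymethyl in place of hydrogen on a nitrogen on an aromatic ring. Going by the values given here, no measured step alters this nitrogen, so the two steps give no direct guide. The step from compound 1 to compound 2 shows that swapping the whole aryl group barely moves this assay, while the step from compound 2 to compound 3 shows that one polar group can cost a great deal. Compound 4 is therefore expected to show a moderate rise, a 2.4-fold higher number from compound 1 to compound 4 (0.38 log units; beyond the scatter). The estimate for compound 4 is 6000 nM, with a range from 1500 nM to 30000 nM.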

Compound 4, half-maximal inhibitory concentration: > 100000 nM
Compound 4: only a limit was reported; the forecaster's own chance of this, stated with the estimate: 10%; at least 16-fold (1.22 log units) between middle value and limit.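

In this assay, going by these compounds alone, carboxymethyl in place of hydrogen on a nitrogen on an aromatic ring gives an at least 39-fold higher number from compound 1 to compound 4 (1.60 log units; beyond the scatter), so this nitrogen, which no earlier step had changed, does not accept every substituent without a large loss. The value of compound 4, > 100000 nM, is a limit of the assay and not a number. A large step is thus no longer confined to a change on an aromatic carbon, and a second compound now stands at the same limit: the limit of > 100000 nM in this assay, at which 2 of the 4 values shown sit.

The compounds shown leave open whether the carboxylic acid or the added chain carries this loss, and what a methyl ester or a plain methyl group on this nitrogen would do. They also do not tell whether a primary amide or a longer chain ending in a carboxylic acid would reach the same limit.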